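The source may report more compounds than this note shows. Statements on the series, on what has been measured and on what is new or still open speak of the compounds shown alone.

Compound 1 `O=C1c2ccccc2N(Cc2ccccc2Cl)S(=O)(=O)N1Cc1ccccc1Cl`: 40400 nM
Compound 2 `O=C1c2ccccc2N(Cc2ccccc2Cl)S(=O)(=O)N1Cc1ccccc1`: 27900 nM

Among the compounds with values here, in a functional assay on CCRF-CEM cells (Homo sapiens) for inhibition (on this read-out lower numbers stand for higher toxicity in this test and higher numbers for lower toxicity in this test), compound 2 stands within the usual scatter of compound 1, the only other measured value; the difference is a 1.4-fold lower number from compound 1 to compound 2 (0.16 log units; within the scatter). Compound 3 `O=C1c2ccccc2N(COCc2ccccc2)S(=O)(=O)N1Cc1ccccc1` differs from compound 2 by benzyloxy in place of 2-chlorophenyl on a saturated chain carbon bound to a sulfonamide nitrogen in a ring. Within the data shown here, no measured step alters the group at that place; the only step available, a 1.4-fold lower number from compound 1 to compound 2 (0.16 log units; within the scatter), concerns a chloro on an aromatic carbon and stayed within the scatter. Nothing here points to a change beyond the scatter. Compound 3 is expected to give 28000 nM, with a range from 10000 nM to 80000 nM. The expected step is a 1.0-fold higher number from compound 2 to compound 3 (0.00 log units; within the scatter).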

Compound 3, half-maximal cytotoxic concentration: 25000 nM
Beside the measured number, compound 3's estimate is 1.1-fold (0.05 log units) above it, within the range that was stated.
By their numbers in this assay, from the lowest: compounds 3, 2 and 1 (each within the scatter of the next).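

Within this assay the only measured change at this place, benzyloxy in place of 2-chlorophenyl on a saturated chain carbon bound to a sulfonamide nitrogen in a ring, gives a 1.1-fold lower number from compound 2 to compound 3 (0.05 log units; within the scatter) and so does not move the number beyond the scatter. This shows that the group at this place can be exchanged for one carrying an oxygen with no measurable consequence in this test. No evidence is available to explain this result. On these data alone, whether an amine or a carboxylic acid at this place would give a step beyond the scatter remains open.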